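A few compounds are considered here, and "the series" means these few. Any claim that something is new, unique, unknown or untested is made for them only; others in the source may bear on it.

The series rests on a small core, first seen in compound 1 `CCn1nnc2c(Br)cccc21`, for which an ADME assay on microsomes from liver (Rattus norvegicus, strain Wistar) for metabolic stability, tested at 2.5 uM (on this read-out lower numbers stand for slow clearance and higher numbers for fast clearance), holds no number: in this assay compound 1 gives "not determined" (no result reported). For the measured compounds named here, compound 2 `FC(F)(F)c1cc(Br)c2nnn(CC3CC3)c2c1` carries a cyclopropylmethyl on one ring nitrogen and a trifluoromethyl on the all-carbon ring, and in this assay compound 2 gives 0.2 mL/min/g, the only number so far in this assay and therefore the only anchor for what follows. Compound 3 `Clc1cc(Br)c2nnn(CC3CC3)c2c1` differs from compound 2 in one place: chloro in place of trifluoromethyl on an aromatic carbon. Going by the values given here, no measured pair shows how this assay answers such a change, so the expectation leans on compound 2 alone. Clearance for compound 3 is expected to stay low, with a step from compound 2 of a 2.0-fold higher number from compound 2 to compound 3 (0.30 log units; within the scatter) that would sit within the usual scatter or just beyond it, toward faster clearance. Compound 3 is thus estimated at 0.4 mL/min/g, within a range from 0.15 mL/min/g to 1.2 mL/min/g.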

Compound 3, intrinsic clearance in a liver preparation (reported as CLH), per the amount of preparation that the assay uses: 1.1 mL/min/g
Estimate against measurement, compound 3: 2.8-fold (0.44 log units) below; the measured number falls inside the stated range.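

Trading trifluoromethyl for chloro on this aromatic carbon is the first change in the series that this assay can read, and it amounts to a 5.5-fold higher number from compound 2 to compound 3 (0.74 log units; beyond the scatter). The position is therefore not indifferent to what it carries: with the bromo group and the cyclopropylmethyl unchanged, this single replacement of four heavy atoms by one moves the read-out beyond the usual scatter, toward faster clearance. The data shown offer no measurement that accounts for the size of this step.

A single pair cannot tell whether any other group on this carbon, such as a nitrile, a methoxy or an amine, would sit nearer compound 2 or compound 3 in this assay. It also leaves open how the read-out would answer a longer chain in place of the cyclopropylmethyl on the ring nitrogen.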